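This account rests on a few compounds, and the source may have more. Where it says the series, first, only, none or still open, it means among the compounds named here.

In a functional assay on MKN-28 cells (Homo sapiens) for cytotoxicity, read by MTT assay (a higher number here means a weaker inhibitor, a lower number a stronger inhibitor), compound 1 `C=C1C(=O)[C@]23C[C@@]1(Cl)CC[C@H]2[C@@]12C=CC(=O)[C@](C)(C(=O)O1)[C@H]2[C@@H]3C(=O)OCc1ccccc1` gives 6800 nM and compound 2 `C=C1C(=O)[C@]23C[C@@]1(O)CC[C@H]2[C@@]12C=CC(=O)[C@](C)(C(=O)O1)[C@H]2[C@@H]3C(=O)OCc1ccccc1` gives 2500 nM. These two share a core and a benzyloxycarbonyl group. They differ by hydroxy in place of chloro on a saturated ring carbon, and that swap amounts to a 2.7-fold lower number from compound 1 to compound 2 (0.43 log units; beyond the scatter). Compound 3 `C=C1C(=O)[C@]23C[C@@]1(F)CC[C@H]2[C@@]12C=CC(=O)[C@](C)(C(=O)O1)[C@H]2[C@@H]3C(=O)OC` carries fluoro on that same ring carbon and a methoxycarbonyl group, and it gives 4100 nM. This number lies within the usual scatter of the numbers for both other compounds, so compound 3 cannot be ranked against either of them.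

Compound 4 `C=C1C(=O)[C@]23C[C@@]1(F)CC[C@H]2[C@@]12C=CC(=O)[C@](C)(C(=O)O1)[C@H]2[C@@H]3C(=O)OCc1ccccc1` keeps the fluoro of compound 3 and turns methoxycarbonyl into benzyloxycarbonyl: phenyl in place of hydrogen on a saturated chain carbon bound to an oxygen next to a carbonyl group. Among the measured compounds shown here, no measured step changes this ester group, so the data offer no direct guide. For the measured compounds named here, the one measured step, modest in size, lies at the ring carbon and bears on the question only indirectly. It shows what the benzyloxycarbonyl compounds can span: compound 1 at 6800 nM and compound 2 at 2500 nM, each within the scatter of compound 3. A change beyond the scatter in this assay is therefore not expected, in either direction. The expected change is a 1.0-fold lower number from compound 3 to compound 4 (0.01 log units; within the scatter). For compound 4 the estimate is 4000 nM, with an expected range from 1800 nM to 8500 nM.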

Compound 4, half-maximal inhibitory concentration: 9800 nM
Compound 4: middle estimate off by 2.5-fold (0.39 log units), on the low side; measured number above the stated range.
By their numbers in this assay, from the lowest: compounds 2, 3, 1 and 4 (each within the scatter of the next, the first and the last beyond it).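

With fluoro held on the ring carbon, the change from methoxycarbonyl to benzyloxycarbonyl in this assay brings a 2.4-fold higher number from compound 3 to compound 4 (0.38 log units; beyond the scatter), so this ester position, read here through this single step, does affect the number, and the benzyl form is the weaker inhibitor of the pair. The benzyloxycarbonyl compounds now also allow three groups on the ring carbon to be compared: fluoro in place of hydroxy gives a 3.9-fold higher number from compound 2 to compound 4 (0.59 log units; beyond the scatter), whereas fluoro in place of chloro gives a 1.4-fold higher number from compound 1 to compound 4 (0.16 log units; within the scatter), so fluoro and chloro cannot be told apart here, while hydroxy gives a lower number than either. Nothing available gives a cause for these steps.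

As far as these compounds go, the ester change is read only with fluoro on the ring carbon, so its size with hydroxy or chloro there remains open. From the compounds shown here alone, how an ethyl ester, a longer chain or a carboxylic acid at the ester position, or an amine on the ring carbon, would read in this assay also remains unknown from these compounds.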